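Hydrazide in place of methyl ester on the longer chain

This account rests on a few compounds, and the source may have more. Where it says the series, first, only, none or still open, it means among the compounds named here.

Of the compounds shown here, three have been measured in an assay on mitochondria for inhibition of Amine oxidase [flavin-containing] B (Bos taurus), read by fluorescence, with a stated time of 60 min; on this read-out lower numbers stand for stronger inhibition and higher numbers for weaker inhibition. Compound 1 `COC(=O)CN1C(=O)c2ccccc2NC1c1ccccc1` gives 720000 nM. Compound 2 `NNC(=O)CN1C(=O)c2ccccc2NC1c1ccccc1` gives 310000 nM, a shift of a 2.3-fold lower number from compound 1 to compound 2 (0.37 log units; beyond the scatter). Compound 3 `COC(=O)CCN1C(=O)c2ccccc2NC1c1ccccc1` gives 860000 nM, the highest of the three numbers; against compound 1 the step of a 1.2-fold higher number from compound 1 to compound 3 (0.08 log units; within the scatter) lies within the scatter, against compound 2 the step of a 2.8-fold higher number from compound 2 to compound 3 (0.44 log units; beyond the scatter) lies beyond it.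

Compound 4 `NNC(=O)CCN1C(=O)c2ccccc2NC1c1ccccc1` has not been measured. It differs from compound 3 by aminoamino in place of methoxy on a carbonyl carbon. The same exchange has been made once already, from compound 1 to compound 2, and gave a 2.3-fold lower number from compound 1 to compound 2 (0.37 log units; beyond the scatter), a modest lowering beyond the scatter. Among the compounds with values here, only that one step bears on the change; the data show nothing on whether the longer chain alters its effect. The expectation is therefore a lowering of similar size, a 2.3-fold lower number from compound 3 to compound 4 (0.37 log units; beyond the scatter), in this assay.

For compound 4 the estimated value in this assay is 370000 nM, with a range from 180000 nM to 800000 nM.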

Compound 4, half-maximal inhibitory concentration: 210000 nM
For compound 4 the middle estimate is 1.8-fold (0.25 log units) above the measured one, within the range that was stated.
By their numbers in this assay, from the lowest: compounds 4 and 2 (each within the scatter of the next); then compounds 1 and 3 (each within the scatter of the next).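

The change from methoxy to aminoamino on a carbonyl carbon now has a second instance, with a 4.1-fold lower number from compound 3 to compound 4 (0.61 log units; beyond the scatter) in this assay, and the lowering holds on both chain lengths: the same change on two cores in this assay, a 2.3-fold lower number (0.37 log units; beyond the scatter) from compound 1 to compound 2 and a 4.1-fold lower number (0.61 log units; beyond the scatter) from compound 3 to compound 4, 1.8-fold (0.25 log units) apart, within the scatter of two such steps

The added chain carbon makes no readable difference with the aminocarbamoyl end group, a 1.5-fold lower number from compound 2 to compound 4 (0.17 log units; within the scatter), as with the methoxycarbonyl end group, a 1.2-fold higher number from compound 1 to compound 3 (0.08 log units; within the scatter). Across these four compounds the end group therefore counts for more than the chain length, and the step that changes the chain and the end group together, a 3.4-fold lower number from compound 1 to compound 4 (0.54 log units; beyond the scatter), remains modest.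

As far as these compounds go, whether a carboxylic acid or a primary amide on this carbonyl carbon would move the number further stays open. So does whether the lowering persists on a still longer chain.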